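This account rests on a few compounds, and the source may have more. Where it says the series, first, only, none or still open, it means among the compounds named here.

In a functional assay (QGY7701 cells, Homo sapiens) for inhibition, read by MTT assay, with a stated time of 48 h (on this read-out higher numbers stand for weaker inhibition and lower numbers for stronger inhibition), compound 1 `COc1ccc2c(=O)c(/C=C/C(=O)Nc3cccc(C)c3)coc2c1` reports only a limit, > 100000 nM. Compound 2 `COc1ccc2c(=O)c(/C=C/C(=O)Nc3ccccc3)coc2c1` gives 14000 nM and compound 3 `COc1ccc2c(=O)c(/C=C/C(=O)NCc3ccc(C)cc3)coc2c1` gives 10200 nM, two values within the scatter of each other. Compound 4 `COc1ccc2c(=O)c(/C=C/C(=O)NCc3ccc(F)cc3F)coc2c1` differs from compound 3 in one place: 2,4-difluorophenyl in place of 4-methylphenyl on a saturated chain carbon bound to an amide-type nitrogen. Going by the values given here, no measured step makes this exact swap, so the guidance is indirect. The step of a 1.4-fold lower number from compound 2 to compound 3 (0.14 log units; within the scatter) also changes this part of the molecule and stays small. The steps of an at least 7.1-fold lower number from compound 1 to compound 2 (0.85 log units; beyond the scatter) and an at least 9.8-fold lower number from compound 1 to compound 3 (0.99 log units; beyond the scatter) are larger, but both start from a limit. The estimated change is therefore none beyond the scatter, a 1.1-fold lower number from compound 3 to compound 4 (0.05 log units; within the scatter). Compound 4 is expected near 9000 nM, within an estimated range from 3000 nM to 30000 nM.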

Compound 4, half-maximal inhibitory concentration: > 100000 nM
Compound 4 gave a limit, no number; the forecaster's own chance of this, stated with the estimate: 10%; middle value at least 11-fold (1.04 log units) away from the limit.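

In this assay, the group on the saturated chain carbon bound to the amide-type nitrogen proves able to matter: 2,4-difluorophenyl in place of 4-methylphenyl gives an at least 9.8-fold higher number from compound 3 to compound 4 (0.99 log units; beyond the scatter), whereas the earlier change in this part of the molecule stayed within the scatter. Against the plain phenyl amide, 2,4-difluorobenzyl gives an at least 7.1-fold higher number from compound 2 to compound 4 (0.85 log units; beyond the scatter). Compound 4 gives only a limit, as compound 1 does, so the step between them cannot be read: the limit of > 100000 nM in this assay, at which 2 of the 4 values shown sit.

The compounds shown leave open whether both fluorines are needed for this weakening, as a benzyl carrying a single fluorine would tell. As far as these compounds go, how an amine or a carboxylic acid on that ring would read also remains open.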